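Swapping a benzyl arm for a thiophene in a CXCR4 antagonist

A few compounds are considered here, and "the series" means these few. Any claim that something is new, unique, unknown or untested is made for them only; others in the source may bear on it.

Measured compounds:
Compound 1, `NCc1ccc(CN(Cc2nc3ccccc3[nH]2)C2CCCc3cccnc32)c(CN)c1`: 10 nM
Compound 2, `COCc1ccc(CN(Cc2nc3ccccc3[nH]2)C2CCCc3cccnc32)c(CN)c1`: 21 nM

Both compounds were tested in a functional assay on CEM-CCRF cells for antagonist activity at C-X-C chemokine receptor type 4 (Homo sapiens), read by calcium flux; a higher number here means a weaker inhibitor, a lower number a stronger inhibitor. Compound 2 stands at the higher of the two numbers, with compound 1 the nearer and only neighbour. Going by the values given here, the one step known, a 2.1-fold higher number from compound 1 to compound 2 (0.32 log units; beyond the scatter), came from a single small change on a side arm of the shared core.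

Compound 3, `NCc1sccc1CN(Cc1nc2ccccc2[nH]1)C1CCCc2cccnc21`, is not yet measured. It differs from compound 2 by a group of 7 heavy atoms (5 carbon, 1 nitrogen, 1 sulfur; one five-membered aromatic ring with 1 hetero atom) in place of a group of 11 heavy atoms (9 carbon, 1 nitrogen, 1 oxygen; one six-membered aromatic ring of carbon only), on a saturated chain carbon bound to an amine nitrogen. This is a larger change than the measured step: the ring itself is exchanged and the methoxy-bearing chain is lost, while the aminomethyl group stays. Among the compounds with values here, no measured step covers a ring exchange of this kind, so the measured step only shows that changes on this arm have so far shifted the number modestly.

On that basis compound 3 is expected to give about 30 nM, within 8 nM to 120 nM, corresponding to an estimated step of a 1.4-fold higher number from compound 2 to compound 3 (0.15 log units; within the scatter).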

Compound 3, half-maximal inhibitory concentration: 60 nM
Beside the measured number, compound 3's estimate is 2.0-fold (0.30 log units) below it; measured number inside the range.
By their numbers in this assay, from the lowest: compound 1; then compound 2; then compound 3.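

The whole arm can be exchanged, ring included, and the compound stays active, though weaker: the five-membered aromatic ring with 1 hetero atom gives a 2.9-fold higher number from compound 2 to compound 3 (0.46 log units; beyond the scatter) and, set against the compound with the lowest number, a 6.0-fold higher number from compound 1 to compound 3 (0.78 log units; beyond the scatter). The six-membered aromatic ring of carbon only is therefore not essential at this place, yet both compounds that carry it give lower numbers than compound 3. No measured information explains this rise.

Compound 3 exchanges the ring and loses the other side chain in one move, so the share of each in the step stays unresolved. From the compounds shown here alone, whether a furan ring, or a longer chain such as aminoethyl in place of aminomethyl, would bring the number back towards that of compound 1 remains open.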